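Fluoro for Trifluoromethyl: What to Expect of Compound 3

The source may hold more compounds than are shown below. What is called first, only, known or untested is meant among the compounds shown, and "the series" means these compounds.

Compound 1 `COc1cc(C2=NN(C(C)=O)C(c3cc(OC)c(OC)c(OC)c3)O2)cc(OC)c1OC` gives -1.4% in a functional assay on BGC-823 cells (Homo sapiens) for antiproliferative activity, read by MTT assay, tested at 5 uM; on this read-out lower numbers stand for a weaker effect and higher numbers for a stronger effect at the one concentration tested.
Compound 2 `COc1cc(C(=O)N/N=C/c2ccc(C(F)(F)F)cc2)cc(OC)c1OC` gives 56.3% in this assay.

Of the two numbers measured, compound 2 stands highest. Its nearest neighbour is compound 1, whose number sits far lower, a gap well beyond the usual scatter of this kind of measurement. The two compounds share the same trimethoxy-bearing fragment but are otherwise built quite differently, so nothing can be said about any single change between them.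

Compound 3 `COc1cc(C(=O)N/N=C/c2ccc(F)cc2)cc(OC)c1OC` has not yet been measured. It is compound 2 with one change: fluoro in place of trifluoromethyl on an aromatic carbon. The trifluoromethyl group leaves and a single fluoro takes its place on the same aromatic carbon. Going by the values given here, no pair of measured compounds shows what such a swap does here, so the expectation rests on compound 2 alone. A moderate weakening is expected in this assay, though a step within the scatter cannot be ruled out. Compound 3 is therefore expected to give about 42%, within a range from 18% to 66%. This estimate means a step of a number 14.3 percentage points lower from compound 2 to compound 3 (beyond the scatter).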

Compound 3, a percentage reported as inhibition, at one concentration (the size of the read-out at that concentration, not a potency): 61.1%
Compound 3: the middle estimate sits 19.1 percentage points below what was measured; measured number inside the range.
By their numbers in this assay, from the lowest: compound 1; then compounds 2 and 3 (each within the scatter of the next).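

In this assay, going by these compounds alone, putting fluoro in place of trifluoromethyl on this aromatic carbon, para to a large group, gives a number 4.8 percentage points higher from compound 2 to compound 3 (within the scatter), and this is the first single change that can be read directly in this small set. The result shows that, at this one position and at the one concentration tested, a group of 1 heavy atom and a group of 4 heavy atoms cannot be told apart, so the size of the swap does not translate into a clear change in the read-out. The data shown offer no measured property of these compounds that could account for this match.

Going by these compounds, two groups on one aromatic carbon are a narrow basis, so it stays open whether the same flat picture would hold for a very different group in that place, such as an amine, a carboxylic acid or a longer chain, or for plain hydrogen. The compounds shown also leave open whether compound 2 and compound 3 would still match at other concentrations, since a single-concentration read-out is not a potency.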